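Swapping the Aryl Group on the Amine Nitrogen

The compounds below may be only part of what the source reports. "The series", "measured", "known", "first", "only" and "open" are said of these compounds alone.

Compound 1, `COc1ccc(Nc2nc(SCc3cn(Cc4ccccc4Cl)nn3)nc(-c3ccccc3)c2C#N)cc1`, gives 7560 nM in a functional assay on MGC-803 cells (Homo sapiens) for inhibition, read by MTT assay, with a stated time of 72 h; on this read-out higher numbers stand for weaker inhibition and lower numbers for stronger inhibition.
Compound 2, `N#Cc1c(Nc2cccc(C(F)(F)F)c2)nc(SCc2cn(Cc3ccccc3Cl)nn2)nc1-c1ccccc1`, gives 22800 nM in this assay.
Compound 3, `N#Cc1c(Nc2cccc([N+](=O)[O-])c2)nc(SCc2cn(Cc3ccccc3Cl)nn2)nc1-c1ccccc1`, gives 43100 nM in this assay.

These three compounds share one core and differ only in the group attached to a nitrogen on an aromatic ring. Compound 3 has the highest number of the three; the gap a 1.9-fold higher number from compound 2 to compound 3 (0.28 log units; within the scatter) is within the scatter, so compound 2 and compound 3 cannot be told apart, while a 5.7-fold higher number from compound 1 to compound 3 (0.76 log units; beyond the scatter) is beyond it. Compound 4, `Cc1ccccc1Nc1nc(SCc2cn(Cc3ccccc3Cl)nn2)nc(-c2ccccc2)c1C#N`, is not yet measured. It differs from compound 3 in one place: 2-methylphenyl in place of 3-nitrophenyl on a nitrogen on an aromatic ring. For the measured compounds named here, the steps that bear on this are those that change the same group: a 3.0-fold higher number from compound 1 to compound 2 (0.48 log units; beyond the scatter) and a 5.7-fold higher number from compound 1 to compound 3 (0.76 log units; beyond the scatter), both modest. Going by the values given here, each group tried at this position so far has moved the number by a modest amount, so a modest step is expected in this assay, most likely downward toward compound 1. Compound 4 is therefore estimated at 12000 nM, with a range from 4000 nM to 40000 nM, an expected step of a 3.6-fold lower number from compound 3 to compound 4 (0.56 log units; beyond the scatter).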

Compound 4, half-maximal inhibitory concentration: 7280 nM
For compound 4 the middle estimate is 1.6-fold (0.22 log units) above the measured one; measured number inside the range.
By their numbers in this assay, from the lowest: compounds 4 and 1 (each within the scatter of the next); then compounds 2 and 3 (each within the scatter of the next).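

In this assay, 2-methylphenyl brings the number back down from both groups that had raised it: there is a 5.9-fold lower number from compound 3 to compound 4 (0.77 log units; beyond the scatter) and a 3.1-fold lower number from compound 2 to compound 4 (0.50 log units; beyond the scatter) for the two steps. Set against the first compound, there is a 1.0-fold lower number from compound 1 to compound 4 (0.02 log units; within the scatter) (so these two cannot be told apart). The four groups therefore fall into two pairs, with 2-methylphenyl and 4-methoxyphenyl giving the lower numbers, and a group made of carbon alone does as well here as 4-methoxyphenyl, which carries an oxygen.

No measurement shown gives a reason for this split. Going by these compounds, whether it follows the kind of group or its place on the ring stays open, as both change together in these compounds, and plain phenyl or a ring carrying an amine or a carboxylic acid would add to the picture.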